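The compounds below may be only part of what the source reports. "The series", "measured", "known", "first", "only" and "open" are said of these compounds alone.

Measured compounds in a functional assay on QG-56 cells (Homo sapiens) for antiproliferative activity; on this read-out lower numbers stand for stronger inhibition and higher numbers for weaker inhibition:
Compound 1, `Cn1cncc1C(O)(c1ccc(C#N)cc1)c1cc2cc([N+](=O)[O-])cc(-c3ccccc3)c2o1`: 1480 nM
Compound 2, `Cn1cncc1C(O)(c1ccc(Cl)cc1)c1cc2cc([N+](=O)[O-])cc(-c3ccccc3)c2o1`: 1890 nM

Among the measured compounds shown here, compound 2 has the highest of the two numbers in this assay; the only measured step, a 1.3-fold higher number from compound 1 to compound 2 (0.11 log units; within the scatter), lies within the scatter. Compound 3, `Cn1cncc1C(O)(c1ccc(I)cc1)c1cc2cc([N+](=O)[O-])cc(-c3ccccc3)c2o1`, differs from compound 2 by iodo in place of chloro on an aromatic carbon. For the measured compounds named here, no measured step exchanges one halogen for another; the one step at this position, a 1.3-fold higher number from compound 1 to compound 2 (0.11 log units; within the scatter), did not leave the scatter. Compound 3 is therefore expected to give about 1800 nM, between 900 nM and 3800 nM, which is an estimated 1.1-fold lower number from compound 2 to compound 3 (0.02 log units; within the scatter) and no step beyond the scatter.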

Compound 3, half-maximal inhibitory concentration: > 10000 nM
Compound 3: a limit, no number (the forecaster's own chance of this, stated with the estimate: 5%); middle value at least 5.5-fold (0.74 log units) away from the limit.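

Unlike the earlier exchange of cyano for chloro, which stayed within the scatter, a change at this position on the aromatic carbon para to a large group now registers: iodo in place of chloro gives an at least 5.2-fold higher number from compound 2 to compound 3 (0.72 log units; beyond the scatter), and iodo in place of cyano gives an at least 6.7-fold higher number from compound 1 to compound 3 (0.82 log units; beyond the scatter). The reading for compound 3 is a limit of the assay and not a number, so both steps have only a lower bound: the limit of > 10000 nM in this assay, at which 1 of the 3 values shown sits.

The compounds shown leave open whether bromo would read like chloro or like iodo. They also leave open how an amine or a carboxylic acid would read at this position.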